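Swapping the Anilide Ring in a Weakly Cytotoxic Series

The compounds below may be only part of what the source reports. "The series", "measured", "known", "first", "only" and "open" are said of these compounds alone.

Of the compounds shown here, three built on one shared core have been tested in an ADME assay on SW480 cells (Homo sapiens) for cytotoxicity, read by MTT assay, with a stated time of 72 h; on this read-out higher numbers stand for weaker inhibition and lower numbers for stronger inhibition. Compound 1 `CCOc1ccc(NC(=O)c2cccc(/C=C3\CC(=O)N(Cc4ccccc4)C3=O)c2)cc1` gives 73200 nM in this assay. Compound 3 `O=C(Nc1ccc(Cl)cc1)c1cccc(/C=C2\CC(=O)N(Cc3ccccc3)C2=O)c1` is reported only as > 100000 nM, which is a limit of the assay rather than a number. Compound 2 `COc1ccc(OC)c(NC(=O)c2cccc(/C=C3\CC(=O)N(c4ccccc4)C3=O)c2)c1` likewise gives > 100000 nM, again a limit rather than a measured number. Compound 2 therefore stands at the limit of > 100000 nM in this assay, at which 2 of the 3 values shown sit, so its true value lies somewhere beyond that point.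

Compound 4 `CCc1ccc(NC(=O)c2cccc(/C=C3\CC(=O)N(c4ccccc4)C3=O)c2)cc1` has not yet been measured in this assay. It differs from compound 2 in a single place: 4-ethylphenyl in place of 2,5-dimethoxyphenyl on an amide-type nitrogen.

Going by the values given here, only one measured step touches the same part of the molecule, and that is an at least 1.3-fold higher number from compound 1 to compound 3 (0.13 log units; that floor lies within the scatter). It changes a different group than the present one, and its floor lies within the scatter, so it gives little direction. With every measured value sitting at the weak end of the assay range, a step from compound 2 to compound 4 of no more than the scatter is expected, in either direction, and a second reading at the limit is quite possible. Compound 4 is therefore estimated at 100000 nM, within a range from 40000 nM to 250000 nM. That estimate means an expected step of a number no higher from compound 2 to compound 4 (the limit leaves the size open).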

Compound 4, half-maximal inhibitory concentration: > 100000 nM
Compound 4: no number, only a limit; the forecaster's own chance of this, stated with the estimate: 55%; the middle value lies on the limit itself.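

In this assay compound 4 gives > 100000 nM, which is a limit of the assay and not a number. Going by these compounds alone, compound 2 also sits at a limit, and no step from compound 2 to compound 4 can be read. The compounds shown leave open whether 4-ethylphenyl in place of 2,5-dimethoxyphenyl on the amide-type nitrogen changes cytotoxicity at all.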